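The source may hold more compounds than are shown below. What is called first, only, known or untested is meant among the compounds shown, and "the series" means these compounds.

The series shares one core, seen in compound 1 `CCCSc1nc2nc(C)cc(N3CC[C@@H](C)[C@@H](N(C)c4ncnc5[nH]ccc45)C3)n2n1`, which in a functional assay on MGC-803 cells (Homo sapiens) for inhibition, read by MTT assay, with a stated time of 72 h (a lower number here means a stronger inhibitor, a higher number a weaker inhibitor), gives compound 1 15500 nM. Compound 2 `Cc1cc(N2CC[C@@H](C)[C@@H](N(C)c3ncnc4[nH]ccc34)C2)n2nc(SCc3ccc(C(F)(F)F)cc3)nc2n1` gives 2680 nM in this assay, and compound 3 `Cc1cc(N2CC[C@@H](C)[C@@H](N(C)c3ncnc4[nH]ccc34)C2)n2nc(SCc3cc(Cl)ccc3Cl)nc2n1` gives 9850 nM. Compound 3 thus stands second highest of the three numbers: against compound 1 it lies within the scatter, while compound 2 reaches a lower number, as the step of a 3.7-fold higher number from compound 2 to compound 3 (0.57 log units; beyond the scatter) shows. The other measured steps at the same place were a 5.8-fold lower number from compound 1 to compound 2 (0.76 log units; beyond the scatter) and a 1.6-fold lower number from compound 1 to compound 3 (0.20 log units; within the scatter).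

Compound 4 `Cc1cc(N2CC[C@@H](C)[C@@H](N(C)c3ncnc4[nH]ccc34)C2)n2nc(SCc3nc4ccccc4[nH]3)nc2n1` differs from compound 3 by 1H-benzimidazol-2-yl in place of 2,5-dichlorophenyl on a saturated chain carbon bound to a sulfur. The three measured steps bear on it only in showing that changing the group on the saturated chain carbon bound to a sulfur has so far moved this assay by modest amounts in either direction; none of them involves a group carrying a hydrogen-bond donor, so the direction for compound 4 is open. Compound 4 is therefore expected to stay close to compound 3, with the step of a 1.6-fold lower number from compound 3 to compound 4 (0.22 log units; within the scatter) estimated at no more than a modest size. The estimate for compound 4 in this assay is 6000 nM, within the range 1500 nM to 25000 nM.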

Compound 4, half-maximal inhibitory concentration: 21200 nM
Compound 4: the middle estimate sits 3.5-fold (0.55 log units) below what was measured; the measured number falls inside the stated range.
By their numbers in this assay, from the lowest: compound 2; then compounds 3, 1 and 4 (each within the scatter of the next, the first and the last beyond it).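

In this assay, among the compounds shown here, 1H-benzimidazol-2-yl, the only group here at this place on a saturated chain carbon bound to a sulfur that carries a hydrogen-bond donor, brings no gain over either aryl group: the change gives a 2.2-fold higher number from compound 3 to compound 4 (0.33 log units; beyond the scatter), and against 4-(trifluoromethyl)phenyl it gives a 7.9-fold higher number from compound 2 to compound 4 (0.90 log units; beyond the scatter), the largest step yet seen at this place. Against ethyl, the same group gives a 1.4-fold higher number from compound 1 to compound 4 (0.14 log units; within the scatter), so a fused pair of aromatic rings does no better here than the short chain, and 4-(trifluoromethyl)phenyl remains the only group clearly ahead of ethyl. Nothing available explains these differences.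

The compounds shown leave open how an amine or a carboxylic acid at this place would read. They also leave open whether a longer chain would match ethyl or move the number.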